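Cyclopropane-carboxamides: shifting a fluorine on the aryl ring

This account rests on a few compounds, and the source may have more. Where it says the series, first, only, none or still open, it means among the compounds named here.

Measured compounds:
compound 1, `CC[C@H](C)[C@H](N)CN(C(=O)[C@@H]1C[C@H]1c1cccc(Cl)c1)c1ccc(-c2ccccc2)cc1`, 2200 nM in a functional assay for agonist activity at G protein-coupled receptor 88 (Homo sapiens), read by HTRF and cAMP accumulation; on this read-out lower numbers stand for an effect already at smaller amounts and higher numbers for an effect only at larger amounts of compound
compound 2, `CC[C@H](C)[C@H](N)CN(C(=O)[C@@H]1C[C@H]1c1ccc(F)cc1F)c1ccc(-c2ccccc2)cc1`, 1300 nM in this assay

Going by the values given here, compound 2 and compound 1 lie within the scatter of each other; the only step, a 1.7-fold lower number from compound 1 to compound 2 (0.23 log units; within the scatter), is within the scatter, so neither number stands apart. Compound 3, `CC[C@H](C)[C@H](N)CN(C(=O)[C@@H]1C[C@H]1c1c(F)cccc1F)c1ccc(-c2ccccc2)cc1`, differs from compound 2 by 2,6-difluorophenyl in place of 2,4-difluorophenyl on a saturated ring carbon. Among the compounds with values here, no measured step moves a fluorine around the ring, so the single aryl step is the only guide, and it says an aryl change here did not move the number beyond the scatter. Compound 3 is therefore expected near compound 2, at 1800 nM (range 600 nM to 5500 nM), an expected step of a 1.4-fold higher number from compound 2 to compound 3 (0.14 log units; within the scatter).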

Compound 3, half-maximal effective concentration: 11000 nM
The estimate for compound 3 lay 6.1-fold (0.79 log units) below the measured number; measured number above the stated range.
By their numbers in this assay, from the lowest: compounds 2 and 1 (each within the scatter of the next); then compound 3.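

In this assay the arrangement of the two fluorines at this saturated ring carbon matters: with the same atoms, 2,6-difluorophenyl in place of 2,4-difluorophenyl gives an 8.5-fold higher number from compound 2 to compound 3 (0.93 log units; beyond the scatter) and so stands apart from the earlier aryl change. Against 3-chlorophenyl, the same group gives a 5.0-fold higher number from compound 1 to compound 3 (0.70 log units; beyond the scatter) and thus separates compound 3 from both earlier compounds. Nothing available here accounts for this step.

Open, from the compounds shown here alone, is whether an unsubstituted phenyl, a pyridyl or a methoxyphenyl at this carbon would fall with compound 2 or with compound 3. Also open, going by these compounds, is whether the 2,6-difluorophenyl result holds with another group in place of the biphenyl part of the shared core.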